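Aryl versus cyclohexyl on the ring nitrogen

The source may report more compounds than this note shows. Statements on the series, on what has been measured and on what is new or still open speak of the compounds shown alone.

Going by the values given here, compound 2 `O=C1[C@@H](n2cc(-c3ccccc3)nn2)[C@@H](/C=C/c2ccccc2)N1C1CCCCC1` gives 76.8% in a functional assay on KB cells (Homo sapiens) for inhibition, tested at 10 uM (a higher number here means more inhibition of growth at the concentration tested, a lower number less inhibition of growth), and stands highest of the two numbers so far; compound 1 `Cc1ccc(N2C(=O)[C@@H](n3cc(-c4ccccc4)nn3)[C@H]2/C=C/c2ccccc2)cc1` gives 14.7% in this assay. Among the compounds with values here, the one step so far, a number 62.1 percentage points higher from compound 1 to compound 2 (beyond the scatter), is large and beyond the scatter. Compound 3 `O=C1[C@@H](n2cc(-c3ccccc3)nn2)[C@@H](/C=C/c2ccccc2)N1c1ccc(Cl)cc1` carries the change (4-chlorophenyl in place of cyclohexyl on an amide-type nitrogen in a ring), on an amide-type nitrogen in a ring. This reverses the direction of the step from compound 1 to compound 2 in kind, since an aryl group returns where a cyclohexyl stood, so a large downward step is expected, a number 46.8 percentage points lower from compound 2 to compound 3 (beyond the scatter). Compound 3 is estimated at 30%, with a range from 5% to 65%.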

Compound 3, percent growth inhibition at one concentration: 16.8%
Compound 3: middle estimate off by 13.2 percentage points, on the high side; measured number inside the range.
By their numbers in this assay, from the lowest: compounds 1 and 3 (each within the scatter of the next); then compound 2.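

On the amide-type nitrogen in a ring, 4-chlorophenyl in this assay gives the same kind of loss as 4-methylphenyl: a number 60 percentage points lower from compound 2 to compound 3 (beyond the scatter). Between the two aryl compounds, a number 2.1 percentage points higher from compound 1 to compound 3 (within the scatter), so chloro in place of methyl on an aromatic carbon leaves the two numbers within the scatter of each other. Nothing available explains the gap between cyclohexyl and these two aryl groups.

Cyclohexyl is the only non-aromatic group shown on this nitrogen. Going by these compounds, how a cyclopentyl ring, a longer alkyl chain or a chain ending in an amine would compare with compound 2 remains open.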